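Solubility notes on a fused-core series: pentan-3-yl replacement

The compounds below may be only part of what the source reports. "The series", "measured", "known", "first", "only" and "open" are said of these compounds alone.

Measured so far:
compound 1, `COc1cccc(CNCCCNc2ccnc3cc(Cc4ccccc4)ccc23)c1O`: 4200 nM
compound 2, `COc1cccc(CNCCCNc2ccnc3cc(Oc4ccc(F)cc4)ccc23)c1O`: 14500 nM
compound 3, `Fc1ccc(Oc2ccc3c(NCCCNCc4ccco4)ccnc3c2)cc1`: 14500 nM

In a physicochemical assay for solubility, with a stated time of 18 h, at pH 7.4 (on this read-out lower numbers stand for lower solubility and higher numbers for higher solubility), compound 2 gives 14500 nM, level with compound 3 at the digits shown and together with it the highest of the three numbers; the furthest is compound 1, with a 3.5-fold higher number from compound 1 to compound 2 (0.54 log units; beyond the scatter). The change to the furan-2-yl variant, no change at the digits printed from compound 2 to compound 3 (within the scatter), leaves the read-out where it was.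

Compound 4, `CCC(CC)c1ccc2c(NCCCNCc3cccc(OC)c3O)ccnc2c1`, is not yet measured. It differs from compound 2 at the fused core: pentan-3-yl in place of 4-fluorophenoxy on an aromatic carbon. Of the measured steps only a 3.5-fold higher number from compound 1 to compound 2 (0.54 log units; beyond the scatter) concerns this aromatic carbon; there a ring-bearing group with one acceptor replaced a ring-bearing group without one and the number rose by a modest amount beyond the scatter. Going by the values given here, the entering group here carries no ring and no acceptor, so a step of roughly that size in the opposite direction is the working expectation, though no measured pair shows a chain at this position. Compound 4 is therefore expected to give 6000 nM in this assay, within 2500 nM to 15000 nM, which means an estimated 2.4-fold lower number from compound 2 to compound 4 (0.38 log units; beyond the scatter).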

Compound 4, solubility: 4200 nM
Estimate against measurement, compound 4: 1.4-fold (0.15 log units) above; measured number inside the range.
By their numbers in this assay, from the lowest: compounds 1 and 4 (each within the scatter of the next); then compounds 2 and 3 (each within the scatter of the next).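

In this assay, going by these compounds alone, the change from 4-fluorophenoxy to pentan-3-yl gives the first reading for a group with no ring at this aromatic carbon, and a 3.5-fold lower number from compound 2 to compound 4 (0.54 log units; beyond the scatter) is the size of that step, beyond the scatter and equal in size to the step between compounds 1 and 2. Within the data shown here, the comparison with benzyl is new as well: no change at the digits printed from compound 1 to compound 4 (within the scatter) puts the open chain and the ring-bearing benzyl group within the scatter of each other, so among compounds 1, 2 and 4 the presence of a ring does not track the number, and only 4-fluorophenoxy, the one group of the three with a hydrogen-bond acceptor, stands apart. No measurement offered here accounts for this difference.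

The compounds shown leave open whether the higher number of compound 2 goes with the ether oxygen or with the fluorine of 4-fluorophenoxy, a question that plain phenoxy and methoxy at this aromatic carbon would address. From the compounds shown here alone, it is also open whether pentan-3-yl gives the same step when furan-2-yl stands in place of 2-hydroxy-3-methoxyphenyl, as in compound 3.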